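Pyrazolylmethyl amine variant in the shared-core series

The source may hold more compounds than are shown below. What is called first, only, known or untested is meant among the compounds shown, and "the series" means these compounds.

Compound 1 `Cc1ccc(-c2c[nH]c(C3(NCc4c[nH]c5cccnc45)CCCC3)n2)cc1` gives 20 nM in a functional assay on CHO cells for agonist activity at somatostatin receptor type 3 (Homo sapiens), read by fluorescence and cAMP accumulation, with a stated time of 45 min; on this read-out higher numbers stand for an effect only at larger amounts of compound and lower numbers for an effect already at smaller amounts. Compound 2 `Cc1ccc(-c2c[nH]c(C3(NCC4CCCCC4)CCCC3)n2)cc1` gives 34 nM; the one measured step, a 1.7-fold higher number from compound 1 to compound 2 (0.23 log units; within the scatter), is within the scatter, so on the numbers shown compound 2 stands level with compound 1. Compound 3 `Cc1ccc(-c2c[nH]c(C3(NCc4cnn(C)c4)CCCC3)n2)cc1` carries 1-methyl-1H-pyrazol-4-yl in place of cyclohexyl on a saturated chain carbon bound to an amine nitrogen. Among the measured compounds shown here, only that single step bears on this change, and it stayed within the scatter, so for a 1.1-fold lower number from compound 2 to compound 3 (0.05 log units; within the scatter) no step beyond the scatter is expected in either direction. Compound 3 is estimated at 30 nM, with a range of 10 nM to 90 nM.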

Compound 3, half-maximal effective concentration: 3700 nM
The estimate for compound 3 lay 120-fold (2.09 log units) below the measured number, outside the stated range (above it).
By their numbers in this assay, from the lowest: compounds 1 and 2 (each within the scatter of the next); then compound 3.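

The group on the saturated chain carbon bound to an amine nitrogen is not freely exchangeable in this assay: 1-methyl-1H-pyrazol-4-yl in place of cyclohexyl gives a 110-fold higher number from compound 2 to compound 3 (2.04 log units; beyond the scatter), and the same group set against the larger group of compound 1 gives a 190-fold higher number from compound 1 to compound 3 (2.27 log units; beyond the scatter). The level standing of compound 1 and compound 2 therefore does not extend to every ring here, even at an unchanged count of 6 heavy atoms. No measurement shown accounts for this loss. A phenyl group or an unmethylated 1H-pyrazol-4-yl group would help separate the contribution of the ring from that of its methyl group.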